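Compound 4 Beside Compound 3: Relocating the Ring Hydroxyl

The source may hold more compounds than are shown below. What is called first, only, known or untested is meant among the compounds shown, and "the series" means these compounds.

Of the compounds shown here, three with a shared core have been measured in an assay on cells for inhibition of Amine oxidase [flavin-containing] B (Homo sapiens), read by fluorescence, with a stated time of 30 min, tested at 10 uM; a lower number here means less inhibition, a higher number more inhibition at the concentration tested (going by the name of the read-out). Compound 1 `COc1cc2c(cc1OC)C(=O)/C(=C/c1ccc(CN(C)Cc3ccccc3)c(O)c1)O2` carries a (benzyl(methyl)amino)methyl group on an aromatic carbon, and in this assay compound 1 gives 17.8%. Compound 2 `CCN(Cc1ccccc1)Cc1ccc(/C=C2\Oc3cc(OC)c(OC)cc3C2=O)cc1O` differs by methyl in place of hydrogen on a saturated chain carbon bound to an amine nitrogen, and compound 2 gives 23.9%; the step of a number 6.1 percentage points higher from compound 1 to compound 2 (within the scatter) lies within the scatter. Compound 3 `COc1cc2c(cc1OC)C(=O)/C(=C/c1cccc(O)c1)O2` has hydrogen in place of that aminomethyl group, and compound 3 gives 37%, the highest of the three numbers, with the steps of a number 19.2 percentage points higher from compound 1 to compound 3 (beyond the scatter) and a number 13.1 percentage points higher from compound 2 to compound 3 (beyond the scatter) both beyond the scatter.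

Compound 4 `COc1cc2c(cc1OC)C(=O)/C(=C/c1ccc(O)cc1)O2` is the next candidate. Relative to compound 3 the change is 4-hydroxyphenyl in place of 3-hydroxyphenyl on a double-bonded chain carbon bound to a double-bonded ring carbon. Among the compounds with values here, none of the measured steps bears on this change: all three concern the aminomethyl group or its methyl, not where the hydroxyl sits on the ring. Within the data shown here, with no guiding step, the account expects no movement beyond the scatter, so the step from compound 3 to compound 4 is estimated as a number 2 percentage points lower from compound 3 to compound 4 (within the scatter). Compound 4 is therefore expected to give about 35%, within a range from 15% to 55%.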

Compound 4, a percentage reported as inhibition, at one concentration (the size of the read-out at that concentration, not a potency): 36.1%
For compound 4 the middle estimate is 1.1 percentage points below the measured one; low and high end bracket the measured number.
By their numbers in this assay, from the lowest: compounds 1 and 2 (each within the scatter of the next); then compounds 4 and 3 (each within the scatter of the next).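

Moving the hydroxyl, with 4-hydroxyphenyl in place of 3-hydroxyphenyl on a double-bonded chain carbon bound to a double-bonded ring carbon, gives in this assay a number 0.9 percentage points lower from compound 3 to compound 4 (within the scatter), so the two placements cannot be told apart by this read-out. Within the data shown here, the earlier steps all concerned the aminomethyl group or its methyl, while this is the first step to change only where the hydroxyl sits, and at this one concentration the relocation leaves the number within the scatter, unlike removing the aminomethyl group. No supporting measurement bears on why the two placements read alike.

Only these two hydroxyl placements are shown, so it remains open how a plain phenyl, or a ring bearing a carboxylic acid or a fluorine in place of the hydroxyl, would read at this position, and a single-concentration percentage says nothing about potency. Also open, on these data alone, is whether the aminomethyl groups of compound 1 and compound 2 would give a step of similar size on the 4-hydroxyphenyl ring.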